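Benzodioxinyl Analogue of a Biphenyl Iminosugar Glucosidase Inhibitor

This account rests on a few compounds, and the source may have more. Where it says the series, first, only, none or still open, it means among the compounds named here.

Measured so far:
- Compound 1 `COc1cccc(-c2ccc(COCCCCCN3C[C@H](O)[C@@H](O)[C@H](O)[C@H]3CO)cc2)c1`: 20 nM
- Compound 2 `N#Cc1ccc(-c2ccc(COCCCCCN3C[C@H](O)[C@@H](O)[C@H](O)[C@H]3CO)cc2)cc1`: 3 nM
- Compound 3 `OC[C@@H]1[C@@H](O)[C@H](O)[C@@H](O)CN1CCCCCOCc1ccc(-c2cc(C(F)(F)F)cc(C(F)(F)F)c2)cc1`: 15 nM

The three measured compounds share a core and differ only in the aromatic group at the far end of the biphenyl. In an assay on isolated protein for inhibition of Beta-glucosidase (Homo sapiens) (on this read-out lower numbers stand for stronger inhibition and higher numbers for weaker inhibition), compound 1 gives 20 nM, the highest of the three numbers. Compound 3 sits nearest to it, its value being within the scatter of that of compound 1, so the two cannot be ordered. Compound 2 lies furthest away: a 6.7-fold lower number from compound 1 to compound 2 (0.82 log units; beyond the scatter).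

Compound 4 `OC[C@@H]1[C@@H](O)[C@H](O)[C@@H](O)CN1CCCCCOCc1ccc(-c2ccc3c(c2)OCCO3)cc1` has not yet been measured in this assay. It differs from compound 1 in one place: 2,3-dihydro-1,4-benzodioxin-6-yl in place of 3-methoxyphenyl on an aromatic carbon. Within the data shown here, the only measured step that bears on this position is the one from compound 1 to compound 2, which was modest and beyond the scatter, while compound 3 shows that a quite different substituent at the same place can leave the number close to that of compound 1. Since the fused dioxin ring of compound 4 resembles neither of these changes closely, the expectation is for a step of the size a 1.3-fold lower number from compound 1 to compound 4 (0.12 log units; within the scatter), that is, no change beyond the scatter. For compound 4 the estimated value in this assay is 15 nM, with a range from 5 nM to 45 nM.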

Compound 4, half-maximal inhibitory concentration: 30 nM
The estimate for compound 4 lay 2.0-fold (0.30 log units) below the measured number; the range from low to high includes it.
By their numbers in this assay, from the lowest: compound 2; then compounds 3, 1 and 4 (each within the scatter of the next).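

In this assay, 2,3-dihydro-1,4-benzodioxin-6-yl in place of 3-methoxyphenyl gives a 1.5-fold higher number from compound 1 to compound 4 (0.18 log units; within the scatter), so at this place, on an aromatic carbon para to a large group, the added non-aromatic ring with its second oxygen leaves compound 4 indistinguishable from compound 1. Measured against the nitrile-bearing group, the same position gives a 10-fold higher number from compound 2 to compound 4 (1.00 log units; beyond the scatter), which sets compound 2 apart from compound 4 as well as from compound 1 and shows that the lower number of compound 2 is not shared by either of these two oxygen-bearing groups. No measurement shown accounts for these numbers.

The compounds shown leave open whether the lower number of compound 2 belongs to the nitrile itself or to its place on the ring, a question that a 3-cyanophenyl or a 4-methoxyphenyl group would bear on. They also leave open how an open-chain 3,4-dimethoxyphenyl group, an amine or a carboxylic acid would read at this same place.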